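This account rests on a few compounds, and the source may have more. Where it says the series, first, only, none or still open, it means among the compounds named here.

Three ureas on a shared core have been tested in an ADME assay on BJ cells (Homo sapiens) for cytotoxicity, with a stated time of 72 h; a lower number here means that less compound is needed, a higher number that more compound is needed for the effect. Compound 1 `Cc1cc(NC(=O)Nc2ccc([N+](=O)[O-])c(C(F)(F)F)c2)c2ccccc2n1` reaches only the assay limit there, giving > 25000 nM. Compound 2 `COc1ccc(NC(=O)Nc2cc(C)nc3ccccc23)cc1F` gives 26000 nM in this assay. Compound 3 `Cc1cc(NC(=O)Nc2ncccc2C)c2ccccc2n1` also shows only a limit in this assay, > 25000 nM. Its standing is thus set by the limit of > 25000 nM in this assay, at which 2 of the 3 values shown sit, where most of the values sit. From compound 3 the change 2-fluorophenyl in place of 3-methylpyridin-2-yl on an amide-type nitrogen leads to compound 4 `Cc1cc(NC(=O)Nc2ccccc2F)c2ccccc2n1`. Among the compounds with values here, no measured pair shows how large a step such a change brings, so the expectation rests on the three values alone, which lie close together. The step from compound 3 to compound 4 is therefore expected to be a number no higher from compound 3 to compound 4 (the limit leaves the size open), not beyond the scatter. Compound 4 is estimated at 25000 nM, within a range from 12000 nM to 50000 nM, most likely again reported as a limit.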

Compound 4, half-maximal effective concentration: > 25000 nM
Compound 4 gave a limit, no number; the forecaster's own chance of this, stated with the estimate: 70%; the middle value lies on the limit itself.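

Compound 3 and compound 4 both give only a limit in this assay, not a number, so no step can be read between them. Left open is whether 2-fluorophenyl in place of 3-methylpyridin-2-yl changes this read-out at all.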